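A few compounds are considered here, and "the series" means these few. Any claim that something is new, unique, unknown or untested is made for them only; others in the source may bear on it.

Values so far in a functional assay on MCF7 cells (Homo sapiens) for inhibition, read by CCK-8 assay, with a stated time of 48 h (on this read-out higher numbers stand for weaker inhibition of growth and lower numbers for stronger inhibition of growth), are these.
- Compound 1 `CN1CCN(c2ccc(Nc3ncc(Cl)c(NCc4ccc(F)cc4)n3)nc2)CC1` gives 19300 nM in this series.
- Compound 2 `CN1CCN(c2ccc(Nc3ncc(Cl)c(NCc4ccco4)n3)nc2)CC1` gives 21300 nM in this series.

Compound 2 stands level with compound 1, and the step of a 1.1-fold higher number from compound 1 to compound 2 (0.04 log units; within the scatter) lies within the scatter. Compound 3 `Cc1cccc(Nc2nc(Nc3ccc(N4CCN(C)CC4)cn3)ncc2Cl)c1` carries 3-methylphenyl in place of (furan-2-yl)methyl on a nitrogen on an aromatic ring relative to compound 2. Among the measured compounds shown here, the one measured step bears on this only in part, since it swaps furan-2-yl for 4-fluorophenyl and keeps the saturated chain carbon that compound 3 lacks. For the measured compounds named here, no measured compound shows the effect of losing that carbon. A shift beyond the scatter in this assay is therefore not expected, though the range stays wide. The expected step is a 1.4-fold lower number from compound 2 to compound 3 (0.15 log units; within the scatter) on this estimate. For compound 3 the estimated value is 15000 nM with 5000 nM to 40000 nM as the expected range.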

Compound 3, concentration for 50% growth inhibition: 7160 nM
Compound 3: middle estimate off by 2.1-fold (0.32 log units), on the high side; measured number inside the range.
By their numbers in this assay, from the lowest: compound 3; then compounds 1 and 2 (each within the scatter of the next).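

In this assay, among the compounds shown here, the group on this nitrogen moves the number beyond the scatter for the first time: the change to 3-methylphenyl gives a 3.0-fold lower number from compound 2 to compound 3 (0.47 log units; beyond the scatter) and a 2.7-fold lower number from compound 1 to compound 3 (0.43 log units; beyond the scatter). Both steps are modest and run the same way from two different starting groups, whereas exchanging the ring while keeping the saturated chain carbon gave only a 1.1-fold higher number from compound 1 to compound 2 (0.04 log units; within the scatter), within the scatter. Nothing measured here accounts for the shift.

The compounds shown leave open whether the lower number follows from losing the saturated chain carbon, from the methyl on the ring, or from both, since the two changes arrive together in compound 3. A plain phenyl or a 3-methylbenzyl group on the same nitrogen would help separate these two changes.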